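Compound 1 to compound 4: hydroxy to 2-aminophenyl

A few compounds are considered here, and "the series" means these few. Any claim that something is new, unique, unknown or untested is made for them only; others in the source may bear on it.

In a functional assay on MV4-11 cells (Homo sapiens) for antiproliferative activity, read by CCK-8 assay, with a stated time of 72 h (a lower number here means a stronger inhibitor, a higher number a weaker inhibitor), compound 1 (`Cn1cc(-c2ccccc2Oc2ccccc2)c2cc(C(=O)NCCCCCCC(=O)NO)[nH]c2c1=O`) gives 180 nM and compound 3 (`Cc1ccccc1-c1cn(C)c(=O)c2[nH]c(C(=O)NCc3ccc(C(=O)Nc4ccccc4N)cc3)cc12`) gives 310 nM as its reading, and these two values lie within the scatter of each other. Compound 2 (`Cn1cc(-c2cc(C(C)(C)O)ccc2OC2CC2)c2cc(C(=O)NCc3ccc(C(=O)NO)cc3)[nH]c2c1=O`) gives 420 nM in this assay as its reading. That value is higher than the value of compound 1 by a margin beyond the scatter, but it stays within the scatter of the value of compound 3. Within the data shown here, the three measured compounds differ in more than one place, so no single-change step is available yet.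

Compound 4 (`Cn1cc(-c2ccccc2Oc2ccccc2)c2cc(C(=O)NCCCCCCC(=O)Nc3ccccc3N)[nH]c2c1=O`) differs from compound 1 at one place only, with 2-aminophenyl in place of hydroxy on an amide-type nitrogen as the change: 2-aminophenyl in place of hydroxy on an amide-type nitrogen. Compound 3 at 310 nM already carries a (2-aminophenyl)carbamoyl group and stays within the scatter of compound 1, but it differs elsewhere too and is only a loose guide. A moderate step to a higher number, beyond the scatter, is expected in this assay for this change. The expected step is a 4.4-fold higher number from compound 1 to compound 4 (0.65 log units; beyond the scatter) as a rough estimate. The expected value for compound 4 is 800 nM with an estimated range from 280 nM to 2500 nM as the working figure.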

Compound 4, half-maximal inhibitory concentration: 130 nM
Compound 4: middle estimate off by 6.2-fold (0.79 log units), on the high side, outside the stated range (below it).
By their numbers in this assay, from the lowest: compounds 4, 1, 3 and 2 (each within the scatter of the next, the first and the last beyond it).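

In this assay, 2-aminophenyl in place of hydroxy on the amide-type nitrogen gives a 1.4-fold lower number from compound 1 to compound 4 (0.14 log units; within the scatter), so this position accepts the change without a step beyond the scatter, even though one heavy atom gives way to seven and a six-membered aromatic ring enters. Among these compounds, this is the first single-change reading at this place: compound 3 also carries (2-aminophenyl)carbamoyl but differs elsewhere, so it could not separate this change from its other differences. No measured evidence bears on the reason that hydroxy and 2-aminophenyl read within the scatter of each other here.

Going by these compounds, it remains open whether the same change would stay within the scatter on a different chain or with the other substituents on the shared core, such as the cyclopropyl ether and the 2-hydroxypropan-2-yl group of compound 2. On these data alone, it also remains open how other groups on this nitrogen would read, for example a 2-hydroxyphenyl, a methyl or a longer chain ending in a carboxylic acid.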